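The source may hold more compounds than are shown below. What is called first, only, known or untested is meant among the compounds shown, and "the series" means these compounds.

This set of compounds was tested in a functional assay on A549 cells (Homo sapiens) for inhibition, read by CCK-8 assay, with a stated time of 48 h; on this read-out lower numbers stand for stronger inhibition and higher numbers for weaker inhibition. Compound 1 `COc1cc(-c2cc3nccc(-c4c[nH]c5ccccc45)n3n2)cc(OC)c1OC` gives only a limit here, > 10000 nM, which is the limit of > 10000 nM in this assay, at which 1 of the 3 values shown sits. Compound 2 `COc1cc(-c2ccnc3cc(-c4ccc5cc[nH]c5c4)nn23)cc(OC)c1OC` gives 170 nM in this assay, and compound 3 `COc1cc(-c2ccnc3cc(-c4cn(C(=O)OC(C)(C)C)c5ccccc45)nn23)cc(OC)c1OC` gives 2070 nM. Of the two compounds with a measured number, compound 2 stands lowest, and compound 3 sits clearly above it, with a gap wider than the usual scatter of repeated measurements. Compounds 2 and 3 differ in more than one place, so that gap cannot be tied to a single change.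

Compound 4 `COc1ccc(-c2cc3nccc(-c4cc(OC)c(OC)c(OC)c4)n3n2)cc1N` has not yet been measured. It differs from compound 2 in one place: 3-amino-4-methoxyphenyl in place of 1H-indol-6-yl on an aromatic carbon. Among the compounds with values here, no pair of measured compounds that differ in just one place is at hand, so the size of this step can only be guessed from the change itself, which swaps one aromatic group for another at the same place on the shared core. For compound 4 a step of a 2.9-fold higher number from compound 2 to compound 4 (0.47 log units; beyond the scatter) is expected, a modest weakening that may still fall inside the scatter. Compound 4 is therefore estimated at 500 nM, with a likely range from 120 nM to 2500 nM.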

Compound 4, half-maximal inhibitory concentration: 138 nM
Beside the measured number, compound 4's estimate is 3.6-fold (0.56 log units) above it; the measured number falls inside the stated range.
By their numbers in this assay, from the lowest: compounds 4 and 2 (each within the scatter of the next); then compound 3. At a limit, above all of these: compound 1.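

Within the data shown here, replacing 1H-indol-6-yl with 3-amino-4-methoxyphenyl on this aromatic carbon of the shared core gives, in this assay, a 1.2-fold lower number from compound 2 to compound 4 (0.09 log units; within the scatter), the first step in this set that can be tied to a single change. At this place, then, a group with one six-membered aromatic ring of carbon only performs on a par with a group that also carries a five-membered aromatic ring, so for this pair the two-ring indole is not required to keep the number where it stands. Nothing measured here accounts for why these two different groups give matching numbers.

As far as these compounds go, it remains open which part of the new group matters, as the amine and the methoxy group are present only together, so a phenyl ring carrying just one of them, or neither, would be needed to separate their contributions. From the compounds shown here alone, it is also open how far this place tolerates other kinds of group, such as a carboxylic acid, a pyridine ring or a longer alkyl chain.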